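This account rests on a few compounds, and the source may have more. Where it says the series, first, only, none or still open, it means among the compounds named here.

Of the compounds shown here, three have been tested in an ADME assay on RAW264.7 cells (Mus musculus) for cytotoxicity, read by MTT assay, with a stated time of 48 h; on this read-out lower numbers stand for higher toxicity in this test and higher numbers for lower toxicity in this test. Compound 1, `C#CCN(c1nc(-c2ccccc2)no1)C1CCCCC1`, carries a short propargyl arm on the amine of its core, and in this assay compound 1 gives 32.1 ug/mL. Compound 3, `C#CCN(c1nc(-c2ccc(OC)cc2)no1)C1CCCCC1`, keeps that core but differs by methoxy in place of hydrogen on an aromatic carbon; in this assay compound 3 gives 28 ug/mL. The step between them is a 1.1-fold lower number from compound 1 to compound 3 (0.06 log units; within the scatter). Compound 2, `CC(=O)OC[C@H]1O[C@H](OC[C@@H](Cn2cc(CN(c3nc(-c4ccccc4)no3)C3CCCCC3)nn2)OC(C)=O)C=C[C@@H]1OC(C)=O`, replaces the propargyl arm with a much larger sugar-bearing triazole side chain; the difference between the cores of compound 1 and compound 2 is not broken down here. In this assay compound 2 gives 28.6 ug/mL, a value that sits within the scatter of both compound 1 and compound 3.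

Compound 4, `COc1ccc(-c2noc(N(Cc3cn(C[C@H](CO[C@@H]4C=C[C@H](OC(C)=O)[C@@H](COC(C)=O)O4)OC(C)=O)nn3)C3CCCCC3)n2)cc1`, has not yet been measured. It relates to compound 2 in the same way as compound 3 relates to compound 1, by methoxy in place of hydrogen on an aromatic carbon, and the surroundings of the change are described in the same words in both pairs. Because the step of a 1.1-fold lower number from compound 1 to compound 3 (0.06 log units; within the scatter) was within the scatter, the same change on the larger core of compound 2 is expected to make a similarly small step, estimated as a 1.1-fold lower number from compound 2 to compound 4 (0.03 log units; within the scatter). On that basis compound 4 is expected to give about 27 ug/mL in this assay, with a range from 15 ug/mL to 50 ug/mL considered likely.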

Compound 4, half-maximal cytotoxic concentration: 86.3 ug/mL
Estimate against measurement, compound 4: 3.2-fold (0.50 log units) below; measured number outside the range, above it.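

In this assay the change from phenyl to 4-methoxyphenyl gives a 3.0-fold higher number from compound 2 to compound 4 (0.48 log units; beyond the scatter) on the core with the sugar-bearing triazole side chain, so compound 4 reads as less toxic in this test than compound 2. The same change does not behave alike on the two cores, and the two steps differ by more than repeated measurements would explain: the same change on two cores in this assay, a 1.1-fold lower number (0.06 log units; within the scatter) from compound 1 to compound 3 and a 3.0-fold higher number (0.48 log units; beyond the scatter) from compound 2 to compound 4, 3.5-fold (0.54 log units) apart, beyond the scatter of two such steps. In this series, then, a step measured on the core with the short propargyl arm cannot simply be carried over to the larger core, but these two pairs do not show why the cores part ways or what the change would do on any third core.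

The compounds shown compare hydrogen with methoxy alone at this place on the ring, so it stays open whether another group there, such as an amine or a carboxylic acid, would also give different steps on the two cores. Going by these compounds, it also stays open which part of the large side chain goes with the difference, something a triazole bearing a plain alkyl chain in place of the sugar could help to separate.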